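Naphthalenyl for phenyl on the sulfur of compound 1

This account rests on a few compounds, and the source may have more. Where it says the series, first, only, none or still open, it means among the compounds named here.

Among the measured compounds shown here, compound 1 `CS(=O)(=O)c1ccc(-c2nc3ccccn3c2Sc2ccccc2)cc1` is the only compound of the three with a number: in a functional assay on MDA-MB-231 cells (Homo sapiens) for inhibition, read by MTT assay, with a stated time of 48 h (on this read-out higher numbers stand for weaker inhibition and lower numbers for stronger inhibition), compound 1 gives 72700 nM. Compound 2 `CCc1ccc(-c2nc3ccccn3c2Sc2ccccc2)cc1` returns only a limit, > 100000 nM. Compound 3 `COc1ccc(-c2nc3ccccn3c2Sc2ccccc2)cc1` likewise returns a limit, > 100000 nM, as noted in the limit of > 100000 nM in this assay, at which 2 of the 3 values shown sit. The measured steps, an at least 1.3-fold higher number from compound 1 to compound 2 (0.13 log units; that floor lies within the scatter), an at least 1.3-fold higher number from compound 1 to compound 3 (0.13 log units; that floor lies within the scatter) and a step that the two limits leave unreadable from compound 2 to compound 3, all vary the group on the aromatic carbon, not the group on the sulfur, and so bear only loosely on compound 4 `CS(=O)(=O)c1ccc(-c2nc3ccccn3c2Sc2cccc3ccccc23)cc1`, which differs from compound 1 by naphthalen-1-yl in place of phenyl on a sulfur. For the measured compounds named here, no measured step touches the sulfur substituent, so the direction is open. He therefore expects for compound 4 a step of a 1.5-fold lower number from compound 1 to compound 4 (0.16 log units; within the scatter), an estimated 50000 nM with a range from 10000 nM to 150000 nM.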

Compound 4, half-maximal inhibitory concentration: 24100 nM
For compound 4 the middle estimate is 2.1-fold (0.32 log units) above the measured one; the range from low to high includes it.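

In this assay, among the compounds shown here, the group on the sulfur proves able to move the number: naphthalen-1-yl in place of phenyl gives a 3.0-fold lower number from compound 1 to compound 4 (0.48 log units; beyond the scatter), the first step that is readable as beyond the scatter. The change adds a second six-membered aromatic ring of carbon only, with no hydrogen-bond donors or acceptors on either group, so carbon rings alone account for the difference in structure.

From the compounds shown here alone, whether an amine or a carboxylic acid on the naphthalen-1-yl would shift the number further stays open. So does whether this change would give a number for compound 2 and compound 3, which return only limits: the limit of > 100000 nM in this assay, at which 2 of the 4 values shown sit.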